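The source may hold more compounds than are shown below. What is called first, only, known or untested is meant among the compounds shown, and "the series" means these compounds.

Measured so far in an ADME assay on CHO cells (Cricetulus griseus) for inhibition, read by MTT assay; a higher number here means a weaker inhibitor, a lower number a stronger inhibitor:
- compound 1 `CCN(CC)Cc1ccc(C)c(Nc2nc3ccccc3n2Cc2ccc(C#N)cc2)c1O`: > 50000 nM
- compound 2 `CCNCc1cc(Cl)cc(Nc2nc3ccccc3n2Cc2ccc(C(F)(F)F)cc2)c1O`: 33800 nM
- compound 3 `CCN(CC)Cc1cccc(Nc2nc3ccccc3n2Cc2ccc(C#N)cc2)c1O`: > 50000 nM

Compound 1 stands only at a limit of this assay; its value > 50000 nM is a limit and not a number. Compound 3 likewise gives only a limit, > 50000 nM. Among the compounds with values here, compound 2 is the one compound with a number, 33800 nM. Across the three, (the limit of > 50000 nM in this assay, at which 2 of the 3 values shown sit). The step that the two limits leave unreadable from compound 1 to compound 3 therefore cannot be read from the two limits.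

Compound 4 `CCN(CC)Cc1ccc(C)c(Nc2nc3ccccc3n2Cc2ccc(C(F)(F)F)cc2)c1O` is not yet measured. It differs from compound 1 by trifluoromethyl in place of cyano on an aromatic carbon. Within the data shown here, no measured step bears on this change: compound 2 also carries a trifluoromethyl, but it differs from compound 1 in further places as well, so its value shows only that such an analog can land near the limit in this assay. No step beyond the scatter is expected; the expected step is a step that the limit leaves unreadable from compound 1 to compound 4. Compound 4 is therefore estimated at 60000 nM, with a range of 25000 nM to 150000 nM, and is more likely than not to be reported only as a limit.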

Compound 4, half-maximal inhibitory concentration: 33900 nM
Compound 4: middle estimate off by 1.8-fold (0.25 log units), on the high side; the range from low to high includes it.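

In this assay, within the data shown here, trifluoromethyl in place of cyano on this aromatic carbon, para to a large group, gives the first step with a measured number on one side (an at least 1.4-fold lower number from compound 1 to compound 4 (0.16 log units; that floor lies within the scatter)). Compound 1 gives > 50000 nM, which is a limit and not a number. The step therefore has only a floor, and that floor lies within the scatter, so whether this change moves the value at all cannot be said, because one end of the step rests on a limit: the limit of > 50000 nM in this assay, at which 2 of the 4 values shown sit.

From the compounds shown here alone, what a methoxy group or a carboxylic acid would give at this place stays open. Also open, going by these compounds, are whether the same change reads alike on the core of compound 3, and what a longer chain on the amine would do.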